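Swapping an amino alcohol for a pyrrolidine ether

This account rests on a few compounds, and the source may have more. Where it says the series, first, only, none or still open, it means among the compounds named here.

In a functional assay on MCF7 cells (Homo sapiens) for inhibition, read by fluorescence, with a stated time of 72 h (a lower number here means a stronger inhibitor, a higher number a weaker inhibitor), compound 1 (`CCCn1cnc2c(NC(=N)N)nc(N)nc21`) gives 36500 nM and compound 2 (`CC[C@H](N)COc1nc(NC(=N)N)c2ncn(C(C)C)c2n1`) gives 16300 nM. Compound 3 (`CC[C@@H](CO)Nc1nc(NC(=N)N)c2ncn(C(C)C)c2n1`) is the strongest inhibitor of the three at 1600 nM. Compound 4 (`CC(C)n1cnc2c(NC(=N)N)nc(OC[C@@H]3CCCN3)nc21`) has (pyrrolidin-2-yl)methoxy in place of (1-(hydroxymethyl)propyl)amino on an aromatic carbon. Going by the values given here, the one measured step that bears on this is the large 10-fold lower number from compound 2 to compound 3 (1.01 log units; beyond the scatter), which swapped 2-aminobutoxy for that same (1-(hydroxymethyl)propyl)amino. Among the compounds with values here, compound 4 again has an oxygen-linked amine chain, as compound 2 does, but no measured compound carries its five-membered non-aromatic ring. The expected change in this assay is a somewhat smaller one towards weaker inhibition, a 6.3-fold higher number from compound 3 to compound 4 (0.80 log units; beyond the scatter). For compound 4 the estimated value is 10000 nM, with a range of 3000 nM to 30000 nM.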

Compound 4, half-maximal inhibitory concentration: > 100000 nM
Compound 4: no number, only a limit; the forecaster's own chance of this, stated with the estimate: 10%; middle value at least 10-fold (1.00 log units) from the limit.
By their numbers in this assay, from the lowest: compound 3; then compound 2; then compound 1. At a limit, above all of these: compound 4.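

In this assay compound 4 gives > 100000 nM, which is a limit of the assay and not a number. At this position, (pyrrolidin-2-yl)methoxy in place of (1-(hydroxymethyl)propyl)amino gives an at least 62-fold higher number from compound 3 to compound 4 (1.79 log units; beyond the scatter). The oxygen link alone does not set the reading, since with that link kept, pyrrolidin-2-yl in place of 1-aminopropyl gives an at least 6.1-fold higher number from compound 2 to compound 4 (0.78 log units; beyond the scatter).

Still open, as far as these compounds go, is whether the same five-membered ring would fare better on a nitrogen link, as in (pyrrolidin-2-yl)methylamino. Also open, from the compounds shown here alone, is how a six-membered piperidine ring on the oxygen link would read.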